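Methanesulfonamido in place of methoxy on compound 3

This account rests on a few compounds, and the source may have more. Where it says the series, first, only, none or still open, it means among the compounds named here.

Measured so far in a functional assay on MC-38 cells (Mus musculus) for antiproliferative activity; on this read-out lower numbers stand for stronger inhibition and higher numbers for weaker inhibition
Compound 1 `O=S(=O)(Nc1cccc2cc[nH]c12)c1ccc(Cl)cc1` gives 7 ug/mL
Compound 2 `Nc1ccc(S(=O)(=O)Nc2cccc3cc[nH]c23)cc1` gives 6.1 ug/mL
Compound 3 `COc1ccc(S(=O)(=O)Nc2cccc3c(C#N)c[nH]c23)cc1` gives 0.17 ug/mL

Compound 3 has the lowest number of the three, and its gaps to compound 1 and compound 2 both lie beyond the scatter. The next structure is compound 4 `CS(=O)(=O)Nc1ccc(S(=O)(=O)Nc2cccc3c(C#N)c[nH]c23)cc1` and the change is methanesulfonamido in place of methoxy on an aromatic carbon in which methanesulfonamido stands in place of methoxy on an aromatic carbon.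

Going by the values given here, only one measured step bears on this. It is a 1.1-fold lower number from compound 1 to compound 2 (0.06 log units; within the scatter) and it concerns another pair of groups on an aromatic carbon, in compounds that differ from compound 3 in more than one place. That step lies within the scatter, which gives weak support for expecting only a modest shift here. A small move toward a higher number in this assay is expected, with wide margins. The expected change is a 1.8-fold higher number from compound 3 to compound 4 (0.25 log units; within the scatter) on this thin evidence. For compound 4 the estimated value is 0.3 ug/mL with an expected range of 0.08 ug/mL to 1.2 ug/mL in this read-out.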

Compound 4, half-maximal inhibitory concentration: 1.2 ug/mL
Compound 4: middle estimate off by 4.0-fold (0.60 log units), on the low side, within the range that was stated.
By their numbers in this assay, from the lowest: compound 3; then compound 4; then compounds 2 and 1 (each within the scatter of the next).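

In this assay, the site para to a large group is sensitive on this scaffold: methanesulfonamido in place of methoxy gives a 7.1-fold higher number from compound 3 to compound 4 (0.85 log units; beyond the scatter). Going by these compounds alone, the only earlier step at such a site, a 1.1-fold lower number from compound 1 to compound 2 (0.06 log units; within the scatter), with amino in place of chloro, lay within the scatter and came from a different core, so it gave no sign of this sensitivity. No measurement on hand accounts for the shift.

Methanesulfonamido differs from methoxy in both size and hydrogen-bond donors, and this single pair cannot separate those differences. As far as these compounds go, it remains open where a plain amine, a hydroxyl or a carboxylic acid at this site on the core of compound 3 would fall relative to compound 3 and compound 4.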